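A ring swap on the carbonyl of compound 1

The source may hold more compounds than are shown below. What is called first, only, known or untested is meant among the compounds shown, and "the series" means these compounds.

Compound 1 `CCN(CC)S(=O)(=O)c1ccc(S(=O)(=O)N2CCC[C@@H](C(=O)N[C@H]3CC[C@H](OC)CC3)C2)cc1` gives 1350 nM 
Compound 2 `O=C([C@@H]1CCCN(S(=O)(=O)c2ccc(S(=O)(=O)C3CCC3)cc2)C1)N1CCC(F)(F)CC1` gives 9 nM 

Both compounds were tested in a functional assay on MIA PaCa-2 cells (Homo sapiens) for inhibition, read by MTT assay, with a stated time of 7 days (a higher number here means a weaker inhibitor, a lower number a stronger inhibitor), and compound 1 stands highest of the two, which makes it the weaker inhibitor, with a gap to compound 2 well beyond the usual scatter. Compound 3 `CCN(CC)S(=O)(=O)c1ccc(S(=O)(=O)N2CCC[C@@H](C(=O)N3CCC(OC)CC3)C2)cc1` has not been measured yet. It alters compound 1 in one place, on a carbonyl carbon, where 4-methoxypiperidin-1-yl takes the place of (4-methoxycyclohexyl)amino 4-methoxypiperidin-1-yl in place of (4-methoxycyclohexyl)amino on a carbonyl carbon and the rest stays the same. Among the measured compounds shown here, no measured pair shows this change alone, so any forecast is loose. Compound 2 at 9 nM shows that far lower numbers occur among these compounds, so a fall beyond the scatter is expected, though probably not that far. The estimated change is an 11-fold lower number from compound 1 to compound 3 (1.05 log units; beyond the scatter) in this assay and remains only an expectation. For compound 3 the expected value is 120 nM, within an estimated range of 20 nM to 700 nM in this assay.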

Compound 3, half-maximal inhibitory concentration: 140 nM
Estimate against measurement, compound 3: 1.2-fold (0.07 log units) below; the measured number falls inside the stated range.
By their numbers in this assay, from the lowest: compound 2; then compound 3; then compound 1.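

In this assay, the change on the carbonyl carbon alone gives a 9.6-fold lower number from compound 1 to compound 3 (0.98 log units; beyond the scatter), so this one position can move the number well beyond the scatter while the rest of the molecule stays the same. The swap replaces the carbon-only ring with a ring holding one hetero atom, and it also removes the amide hydrogen, taking the hydrogen-bond donor count of the group from 1 to 0. No supporting measurement gives a reason for the step.

These compounds cannot show which part of the swap matters, since both parts happen together. A (4-methoxycyclohexyl)(methyl)amino group, which keeps the carbon-only ring but has no amide hydrogen, would separate them, and a morpholin-4-yl group would test whether the methoxy group is needed.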